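Hydroxypentyl Amide in Place of the Piperazine Amide

The source may report more compounds than this note shows. Statements on the series, on what has been measured and on what is new or still open speak of the compounds shown alone.

Compound 1 `CC(C)(C)c1ccc(C(=O)N2CCC3(CC2)C(=O)N(CC(=O)N2CCNCC2)CN3c2ccccc2)cc1` gives the highest number of the three compounds measured in an assay on HEK293 cells for displacement of a labelled ligand from NPC1-like intracellular cholesterol transporter 1 (Homo sapiens); a higher number here means a weaker inhibitor, a lower number a stronger inhibitor; compound 1 shows 22000 nM. Compound 2 `CCc1nn(CC)c(C2CCN(C(=O)CN3CN(c4ccccc4)C4(CCN(C(=O)c5ccc(C(C)(C)C)cc5)CC4)C3=O)CC2)c1CC` shows 4600 nM, and compound 3 `CS(=O)(=O)N1CCN(C(=O)CN2CN(c3ccccc3)C3(CCN(C(=O)c4ccc(C5CCCCC5)cc4)CC3)C2=O)CC1` shows 6300 nM, each separated from compound 1 by more than the usual scatter, so compound 1 is the weakest of the three. Compound 4 `CC(C)(C)c1ccc(C(=O)N2CCC3(CC2)C(=O)N(CC(=O)NCCCCCO)CN3c2ccccc2)cc1` has not yet been measured. It differs from compound 1 in one place: (5-hydroxypentyl)amino in place of piperazin-1-yl on a carbonyl carbon. For the measured compounds named here, no measured pair differs in just this way, so the step cannot be read from the numbers. A small move toward a lower number is expected, a 1.5-fold lower number from compound 1 to compound 4 (0.17 log units; within the scatter), which may well stay within the scatter. Compound 4 is estimated at 15000 nM, with a range from 5000 nM to 45000 nM.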

Compound 4, half-maximal inhibitory concentration: 9400 nM
Compound 4: middle estimate off by 1.6-fold (0.20 log units), on the high side; the range from low to high includes it.
By their numbers in this assay, from the lowest: compounds 2, 3 and 4 (each within the scatter of the next, the first and the last beyond it); then compound 1.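

On this carbonyl carbon the piperazin-1-yl ring is not needed for binding in this assay: the open-chain (5-hydroxypentyl)amino group gives a 2.3-fold lower number from compound 1 to compound 4 (0.37 log units; beyond the scatter). For the compounds shown here, this is the first single-place change that can be read at this position, and it shows that a group with no ring can replace the ring without a loss. Nothing measured here accounts for the step.

Going by these compounds, it remains open whether the terminal hydroxyl, the chain length or the amide hydrogen matters most. A plain pentyl amide, a shorter hydroxyalkyl chain or a terminal carboxylic acid would help separate these.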